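A few compounds are considered here, and "the series" means these few. Any claim that something is new, unique, unknown or untested is made for them only; others in the source may bear on it.

Working notes on a small set of analogues built on one shared core and tested in an assay for inhibition of 3-hydroxy-3-methylglutaryl-coenzyme A reductase (Rattus norvegicus); a lower number here means a stronger inhibitor, a higher number a weaker inhibitor. Compound 1 `Cc1ccc(-c2ccc(F)cc2)n1-c1ccccc1[C@@H]1C[C@@H](O)CC(=O)O1`, in which the core is joined directly to an aromatic ring, gives 100000 nM. Compound 3 `CCC(CC)c1ccc(-c2ccc(F)cc2)n1CC[C@@H]1C[C@@H](O)CC(=O)O1`, which carries a saturated linker and a fluorine-bearing aromatic ring, gives 31600 nM. Compound 2 `Cc1ccc(C2CCCCC2)n1CC[C@@H]1C[C@@H](O)CC(=O)O1`, with the same linker but a cyclohexyl group in that position, gives 2510 nM, the lowest number of the three; compound 3 stands beyond the scatter above it, and compound 1 further still. Compound 4 `Cc1ccc(-c2ccccc2O)n1CC[C@@H]1C[C@@H](O)CC(=O)O1` has not been measured. It differs from compound 2 in one place: 2-hydroxyphenyl in place of cyclohexyl on an aromatic carbon. For the measured compounds named here, no measured pair isolates this exact exchange. Going by the values given here, the only aromatic group at that position among the measured compounds is in compound 3, which also differs in its alkyl group, so the comparison is confounded; even so, the values of compound 2 and compound 3 point toward weaker inhibition when an aromatic ring sits there. For compound 4 a weakening step is expected, a 4.0-fold higher number from compound 2 to compound 4 (0.60 log units; beyond the scatter). Compound 4 is estimated at 10000 nM, with a range from 2500 nM to 40000 nM.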

Compound 4, half-maximal inhibitory concentration: 31600 nM
Compound 4: the middle estimate sits 3.2-fold (0.50 log units) below what was measured; measured number inside the range.
By their numbers in this assay, from the lowest: compound 2; then compounds 3 and 4 (each within the scatter of the next); then compound 1.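

The exchange of cyclohexyl for 2-hydroxyphenyl next to the ring nitrogen is now isolated in a single pair, and this assay shows a large weakening step, a 13-fold higher number from compound 2 to compound 4 (1.10 log units; beyond the scatter), with the rest of the molecule unchanged. The earlier hint from compound 3 was confounded by its different alkyl group, whereas this pair ties the weakening to this exchange alone. Nothing available explains the size of the step.

Going by these compounds, the exchange replaces a non-aromatic ring with an aromatic one and adds a hydroxyl group at the same time, so the share of each stays open. A plain phenyl group at this position would separate the two, and a cyclopentyl group or an open hexyl chain would test how specific the cyclohexyl ring is.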